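Replacing a Hexyl Chain with 3-Nitrophenyl

The source may report more compounds than this note shows. Statements on the series, on what has been measured and on what is new or still open speak of the compounds shown alone.

Of the compounds shown here, three built on a shared core have been tested in a functional assay on HeLa cells (Homo sapiens) for cytotoxicity, read by WST assay, with a stated time of 48 h; on this read-out lower numbers stand for stronger inhibition and higher numbers for weaker inhibition. Compound 1 `COc1cccc([C@@H]2OC[C@H]([C@@H](O)c3ccc(OC)c(OC)c3)C[C@H]2C/C=C/c2ccc(OC)c(OC)c2)c1` gives 30100 nM in this test. Compound 2 `CCCCCC/C=C/C[C@H]1C[C@@H]([C@@H](O)c2ccccc2)CO[C@@H]1c1ccccc1` gives 7400 nM, the lower of the two actual numbers, and its distance from compound 1 lies beyond the usual scatter of repeated measurements. Compound 3 `COc1ccc(/C=C/C[C@@H]2C[C@@H]([C@@H](OC)c3ccc(OC)c(OC)c3)CO[C@H]2c2ccc(OC)c(OC)c2)cc1OC` is recorded only as a limit, > 100000 nM.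

Compound 4 `O=[N+]([O-])c1cccc(/C=C/C[C@H]2C[C@@H]([C@@H](O)c3ccccc3)CO[C@@H]2c2ccccc2)c1` has not yet been measured. It is compound 2 with 3-nitrophenyl in place of hexyl on a double-bonded chain carbon bound to a double-bonded chain carbon. For the measured compounds named here, no measured pair of compounds shows this change on its own, so any forecast is loose. The nearest guide is compound 1, which also carries an aromatic ring in that place and gives 30100 nM, although it differs from compound 2 elsewhere too. The expected step is a 2.4-fold higher number from compound 2 to compound 4 (0.39 log units; beyond the scatter), a modest move toward higher numbers and weaker inhibition, only a little beyond the scatter. For compound 4 the estimate is 18000 nM, with an expected range from 6000 nM to 55000 nM.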

Compound 4, half-maximal inhibitory concentration: 7850 nM
Compound 4: the middle estimate sits 2.3-fold (0.36 log units) above what was measured, within the range that was stated.
By their numbers in this assay, from the lowest: compounds 2 and 4 (each within the scatter of the next); then compound 1. At a limit, above all of these: compound 3.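

Taking out hexyl and putting in 3-nitrophenyl, on a double-bonded chain carbon bound to a double-bonded chain carbon, gives a 1.1-fold higher number from compound 2 to compound 4 (0.03 log units; within the scatter) in this assay and so no readable difference. On the shared core, this place therefore carries either an open chain with no ring or a bigger group with an aromatic ring and hydrogen-bond acceptors, and the two compounds read alike on this test of cell killing. The earlier compounds shown here could not show this, since compound 1 also has an aromatic ring in that place but differs from compound 2 elsewhere too, so only the new pair isolates this single swap.

On these data alone, this one pair cannot separate the ring from the nitro group, so it stays open whether a plain phenyl, a longer chain, an amine or a carboxylic acid in the same place would also leave the number where it is. Nothing measured here gives a reason why the two numbers sit together.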